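Methylamino for methoxy on the shared core of compound 2

A few compounds are considered here, and "the series" means these few. Any claim that something is new, unique, unknown or untested is made for them only; others in the source may bear on it.

Compound 1 `COc1ncnc2c1c(-c1ccoc1)cn2[C@@H]1O[C@H](CO)[C@@H](O)[C@H]1O` is the shared reference; in a functional assay on A549 cells (Homo sapiens), read by MTT assay, with a stated time of 72 h (a lower number here means a stronger inhibitor, a higher number a weaker inhibitor), compound 1 gives 1160 nM. Compound 2 `COc1ncnc2c1c(-c1cccs1)cn2[C@@H]1O[C@H](CO)[C@@H](O)[C@H]1O` gives 4850 nM in this assay, the highest of the two numbers measured, with a 4.2-fold higher number from compound 1 to compound 2 (0.62 log units; beyond the scatter) separating it from compound 1. Compound 3 `CNc1ncnc2c1c(-c1cccs1)cn2[C@@H]1O[C@H](CO)[C@@H](O)[C@H]1O` differs from compound 2 in that (methylamino in place of methoxy on an aromatic carbon). Going by the values given here, no measured step here touches that change, since the only step known, a 4.2-fold higher number from compound 1 to compound 2 (0.62 log units; beyond the scatter), concerns a different place on the core. With no guide in the data, compound 3 is expected to stay close to compound 2, a 1.4-fold lower number from compound 2 to compound 3 (0.14 log units; within the scatter), within the usual scatter. Compound 3 is therefore estimated at 3500 nM, with a range from 900 nM to 14000 nM.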

Compound 3, half-maximal inhibitory concentration: > 20000 nM
Compound 3: no number, only a limit; the forecaster's own chance of this, stated with the estimate: 5%; at least 5.7-fold (0.75 log units) between middle value and limit.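

Going by these compounds alone, the earlier compounds showed only that the group on the five-membered side of the core, thiophen-2-yl against furan-3-yl, moves the number; this aromatic carbon of the six-membered ring now matters too. In this assay, methylamino in place of methoxy gives an at least 4.1-fold higher number from compound 2 to compound 3 (0.61 log units; beyond the scatter), so a single-atom exchange of oxygen for nitrogen here is enough to carry the step beyond the scatter. Its full size stays unknown, as the value for compound 3 is a limit of the assay and not a number: the limit of > 20000 nM in this assay, at which 1 of the 3 values shown sits.

The compounds shown leave open whether a plain amine or an ethoxy group on this carbon would stay near compound 2. They also leave open whether methylamino gives a similar step alongside furan-3-yl.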